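The source may report more compounds than this note shows. Statements on the series, on what has been measured and on what is new or still open speak of the compounds shown alone.

In an ADME assay on MT4 cells (Homo sapiens) for cytotoxicity, read by MTT assay, with a stated time of 4 days (a lower number here means that less compound is tolerated, a higher number that more compound is tolerated), compound 1 (`O=C(c1ccccc1)c1cc(Cl)ccc1OCCn1ccc(=O)[nH]c1=O`) gives > 337000 nM as a limit. Compound 2 (`O=C(c1ccccc1)c1cc(F)ccc1OCCn1ccc(=O)[nH]c1=O`) stands at > 353000 nM and this too is only a limit. Compound 3 (`Cc1ccc(OCCn2ccc(=O)[nH]c2=O)c(C(=O)c2ccccc2)c1`) differs from compound 2 by methyl in place of fluoro on an aromatic carbon and carries methyl in place of fluoro on an aromatic carbon. For the measured compounds named here, the only measured step on that carbon, fluoro in place of chloro, is a step that the two limits leave unreadable from compound 1 to compound 2 and offers no size to carry over. No step beyond the scatter is therefore expected in this assay and another limit is likely. The expected step that the limit leaves unreadable from compound 2 to compound 3 lies within the scatter. The estimated value for compound 3 is 357000 nM (expected range 180000 nM to 500000 nM).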

Compound 3, half-maximal cytotoxic concentration: > 357000 nM
Compound 3 ended at the assay's limit; the forecaster's own chance of this, stated with the estimate: 85%; the middle value lies on the limit itself.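

For the compounds shown here, compound 1, compound 2 and compound 3 all stand as limits only, and no step among them can be read. The compounds shown leave open whether chloro, fluoro and methyl on that aromatic carbon differ in cytotoxicity at all.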